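The source may report more compounds than this note shows. Statements on the series, on what has been measured and on what is new or still open speak of the compounds shown alone.

Compound 1 `NCc1cccc(CN(Cc2nc3ccccc3[nH]2)C2CCCc3cccnc32)c1` and compound 2 `NCc1ccccc1CN(Cc1nc2ccccc2[nH]1)C1CCCc2cccnc21` share one core and differ only in where the aminomethyl group sits on the phenyl ring. In a functional assay on CEM-CCRF cells for antagonist activity at C-X-C chemokine receptor type 4 (Homo sapiens), read by calcium flux (a higher number here means a weaker inhibitor, a lower number a stronger inhibitor), compound 1 gives 1400 nM, while compound 2 gives 50 nM. For the measured compounds named here, that is a 28-fold lower number from compound 1 to compound 2 (1.45 log units; beyond the scatter), so compound 2 stands lowest of the two numbers, with compound 1 as its only neighbour at a markedly higher value.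

Compound 3 `NC/C=C\CN(Cc1nc2ccccc2[nH]1)C1CCCc2cccnc21` takes the change one stage further: 3-aminoprop-1-en-1-yl in place of 2-(aminomethyl)phenyl on a saturated chain carbon bound to an amine nitrogen. Going by the values given here, the only measured step, the shift of the aminomethyl group from one position to another on the same ring, already moved this assay a long way, which shows the placement of the primary amine matters here. Among the compounds with values here, no measured pair shows what happens when the ring itself is removed, so the direction of the step is uncertain, but the loss of the ring that carries the amine is expected to cost some potency. Compound 3 is therefore expected to show a 6.0-fold higher number from compound 2 to compound 3 (0.78 log units; beyond the scatter). The estimate for compound 3 is 300 nM, within a range from 60 nM to 2000 nM.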

Compound 3, half-maximal inhibitory concentration: 77 nM
Compound 3: middle estimate off by 3.9-fold (0.59 log units), on the high side, within the range that was stated.
By their numbers in this assay, from the lowest: compounds 2 and 3 (each within the scatter of the next); then compound 1.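

In this assay, 3-aminoprop-1-en-1-yl in place of 2-(aminomethyl)phenyl gives a 1.5-fold higher number from compound 2 to compound 3 (0.19 log units; within the scatter), so on this saturated chain carbon bound to an amine nitrogen, a group with no ring and one double bond stays level with the ring-bearing group of compound 2. The same chain, set against the other ring placement, gives an 18-fold lower number from compound 1 to compound 3 (1.26 log units; beyond the scatter), so among these three compounds only compound 1, with its 3-(aminomethyl)phenyl, stands apart, and the presence of the ring alone does not decide the number at this position. No evidence is at hand on what lies behind these numbers.

The compounds shown leave open whether the double bond matters, a question that a saturated 4-aminobutyl chain in place of the 4-aminobut-2-en-1-yl would address. They also leave open whether the primary amine itself is needed, which a hydroxyl or a carboxylic acid in its place would test.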